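The compounds below may be only part of what the source reports. "The series", "measured", "known", "first", "only" and "open" are said of these compounds alone.

Measured so far:
compound 1 `COc1ccccc1-c1n[nH]cc1N1CCNCC1` — > 10000 nM
compound 2 `c1ccc(-c2n[nH]cc2N2CCNCC2)cc1` — > 10000 nM

In an assay on isolated protein for binding affinity to 5-hydroxytryptamine receptor 1E (Homo sapiens) (a higher number here means a weaker inhibitor, a lower number a stronger inhibitor), compound 1 gives > 10000 nM, which is a limit of the assay and not a number. In this assay, among the measured compounds shown here, compound 2 likewise gives > 10000 nM, again a limit and not a number; for compound 2 only this limit is known, and the one further value shown for the series is also a limit. For the measured compounds named here, the one measured step, a step that the two limits leave unreadable from compound 1 to compound 2, cannot be read in size because of the limit of > 10000 nM in this assay, at which 2 of the 2 values shown sit, so the two values say only that neither compound reaches measurable binding.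

Compound 3 `Clc1ccccc1-c1n[nH]cc1N1CCNCC1` is not yet measured. It differs from compound 2 by chloro in place of hydrogen on an aromatic carbon. Going by the values given here, the only step that bears on this position, a step that the two limits leave unreadable from compound 1 to compound 2, sits between two limits and gives no readable size, so no direction beyond the scatter can be expected for the step into compound 3 in this assay. On that footing compound 3 is expected to stay at the same level as compound 2, a step that the limit leaves unreadable from compound 2 to compound 3. Compound 3 is therefore estimated at 15000 nM, with a range from 4000 nM to 60000 nM, most likely reported again only as a limit.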

Compound 3, inhibition constant: > 10000 nM
Compound 3: a limit, no number; the forecaster's own chance of this, stated with the estimate: 75%; the middle value does not contradict the limit.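

In this assay compound 3 gives > 10000 nM, a limit and not a number. No step among compound 1, compound 2 and compound 3 can be read in size, because all three values stop at the same point: the limit of > 10000 nM in this assay, at which 3 of the 3 values shown sit.

The compounds shown leave open whether any group at this place gives measurable binding.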